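The source may hold more compounds than are shown below. What is called first, only, known or untested is meant among the compounds shown, and "the series" means these compounds.

Compound 1 `O=C(CN1CCN(S(=O)(=O)c2ccc(F)cc2)CC1)Nc1cc[nH]n1` in an in vitro assay on HEK ts201 cells for negative allosteric modulation of Neuronal acetylcholine receptor; alpha3/beta4 (Homo sapiens), read by fluorescence and calcium flux, with a stated time of 1.5 s (on this read-out lower numbers stand for stronger inhibition and higher numbers for weaker inhibition), gives > 100000 nM, a limit of the assay. Compound 2 `O=C(CN1CCN(S(=O)(=O)c2ccccc2F)CC1)Nc1cc[nH]n1` in this assay gives > 100000 nM, also a limit.

Compound 2 thus stands only at a limit, and both values shown sit at the limit of > 100000 nM in this assay, at which 2 of the 2 values shown sit. Compound 3 `O=C(CN1CCN(S(=O)(=O)c2cccnc2)CC1)Nc1cc[nH]n1` differs from compound 2 by pyridin-3-yl in place of 2-fluorophenyl on a sulfonyl sulfur. Within the data shown here, the one measured step, a step that the two limits leave unreadable from compound 1 to compound 2, cannot be read from the two limits, so it gives no measure of a ring change at this place. The expected step that the limit leaves unreadable from compound 2 to compound 3 is therefore none beyond the scatter. For compound 3 the estimate in this assay is 150000 nM, ranging from 40000 nM to 500000 nM.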

Compound 3, half-maximal inhibitory concentration: > 100000 nM
Compound 3 gave a limit, no number (the forecaster's own chance of this, stated with the estimate: 85%); the middle value is on the limit's open side.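

Among these compounds, no step from compound 1 or compound 2 to compound 3 can be read, since each compound stands only at a limit: the limit of > 100000 nM in this assay, at which 3 of the 3 values shown sit. The compounds shown leave open whether any group on the sulfonyl sulfur changes inhibition in this assay.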